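Adding a Hydroxy Group to Compound 2: Expected Cytotoxicity

This account rests on a few compounds, and the source may have more. Where it says the series, first, only, none or still open, it means among the compounds named here.

Measured so far:
- compound 1 `O=c1nc(NO)c(F)cn1[C@@H]1C[C@@H](O)[C@H](CO)O1`: 920000 nM
- compound 2 `Cc1cn([C@@H]2CC[C@H](CO)O2)c(=O)nc1N`: 1550000 nM

In an ADME assay on HepG2 cells (Homo sapiens) for cytotoxicity, read by MTT assay, with a stated time of 3 days (on this read-out higher numbers stand for lower toxicity in this test and lower numbers for higher toxicity in this test), compound 2 gives the highest of the two numbers, and compound 1 with 920000 nM lies within the scatter of it, so the two cannot be told apart. Compound 3 `Cc1cn([C@@H]2C[C@@H](O)[C@H](CO)O2)c(=O)nc1N` differs from compound 2 by one change: hydroxy in place of hydrogen on a saturated ring carbon. Within the data shown here, with no measured pair showing what such a change does, the step of a 1.1-fold lower number from compound 2 to compound 3 (0.04 log units; within the scatter) is expected to stay within the scatter, in no set direction. Compound 3 is therefore estimated at 1400000 nM, with a range from 600000 nM to 3000000 nM.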

Compound 3, half-maximal cytotoxic concentration: > 2000000 nM
Compound 3 gave a limit, no number (the forecaster's own chance of this, stated with the estimate: 25%); middle value at least 1.4-fold (0.15 log units) from the limit.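

Compound 3 gives a limit and not a number in this assay: the limit of > 2000000 nM in this assay, at which 1 of the 3 values shown sits. Hydroxy in place of hydrogen on a saturated ring carbon gives an at least 1.2-fold higher number from compound 2 to compound 3 (0.11 log units; that floor lies within the scatter), so at this position the new group shows no sign of higher toxicity in this test. The step has a floor only, and how large it really is cannot be read.

As far as these compounds go, whether an amine or a methoxy group on this same ring carbon would also leave the toxicity this low stays open.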